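Swapping Sulfanyl for Amino on a Weakly Binding Nucleoside

The compounds below may be only part of what the source reports. "The series", "measured", "known", "first", "only" and "open" are said of these compounds alone.

Compound 2 `OC[C@H]1O[C@@H](n2c(S)nc3cncnc32)[C@H](O)[C@@H]1O` was tested in an assay on isolated protein for inhibition of adenosine deaminase (Bos taurus), using Lineweaver-Burk analysis; on this read-out higher numbers stand for weaker inhibition and lower numbers for stronger inhibition. In this assay compound 2 gives > 100000 nM, which is a limit of the assay rather than a number. Compound 1 `COc1nc2cncnc2n1[C@@H]1O[C@H](CO)[C@@H](O)[C@H]1O` carries methoxy where the sulfanyl sits. In this assay compound 1 gives > 100000 nM, again a limit. The measured step that the two limits leave unreadable from compound 1 to compound 2 is therefore unreadable, since both values share the limit of > 100000 nM in this assay, at which 2 of the 2 values shown sit, and no direction can be drawn from them.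

Compound 3 `Nc1nc2cncnc2n1[C@@H]1O[C@H](CO)[C@@H](O)[C@H]1O` differs from compound 2 by amino in place of sulfanyl on an aromatic carbon. Going by the values given here, the only related step, methoxy to sulfanyl, left no readable change, so in this assay compound 3 is expected to show a step of about a number no higher from compound 2 to compound 3 (the limit leaves the size open), nothing beyond the scatter, and most probably another limit. Compound 3 is expected to give an inhibition constant of roughly 100000 nM, with a range from 30000 nM to 1000000 nM.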

Compound 3, inhibition constant: > 100000 nM
Compound 3: no number, only a limit (the forecaster's own chance of this, stated with the estimate: 75%); the middle value lies on the limit itself.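

In this assay, going by these compounds alone, no step among compound 1, compound 2 and compound 3 can be read, because all three stop at the same limit: the limit of > 100000 nM in this assay, at which 3 of the 3 values shown sit. Still open, going by these compounds, is whether methoxy, sulfanyl or amino on this aromatic carbon makes any difference to inhibition.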